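A few compounds are considered here, and "the series" means these few. Any claim that something is new, unique, unknown or untested is made for them only; others in the source may bear on it.

Measured so far:
compound 1, `O=C(O)/C(S)=C/c1ccc(Br)cc1`: 1500 nM in an assay on isolated protein for inhibition of Calpain-1 catalytic subunit (Sus scrofa); a higher number here means a weaker inhibitor, a lower number a stronger inhibitor
compound 2, `O=C(O)/C(S)=C/c1c[nH]c2ccc(I)cc12`: 90 nM in this assay

Compound 1 stands at the highest of the two numbers. Compound 2 gives the lower number, and the gap between the two lies well beyond the usual scatter, so compound 2 is the stronger inhibitor of this pair. Compound 1 and compound 2 differ in more than one place, so the gap cannot be traced to any single change.

Compound 3, `O=C(O)/C(S)=C/c1ccc(Cl)cc1`, differs from compound 1 by chloro in place of bromo on an aromatic carbon. Within the data shown here, no pair of measured compounds shows a step of this kind, so its size is open. Exchanging one halogen for another at the same place is expected to move the number little: the step from compound 1 to compound 3, a 1.3-fold higher number from compound 1 to compound 3 (0.12 log units; within the scatter), is estimated to stay within the scatter or lean slightly toward a weaker inhibitor. For compound 3 the expected value in this assay is 2000 nM, with a range from 900 nM to 4500 nM.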

Compound 3, half-maximal inhibitory concentration: 15000 nM
The estimate for compound 3 lay 7.5-fold (0.88 log units) below the measured number; the measured number lies above the stated range.
By their numbers in this assay, from the lowest: compound 2; then compound 1; then compound 3.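

Chloro in place of bromo on an aromatic carbon gives a 10-fold higher number from compound 1 to compound 3 (1.00 log units; beyond the scatter) in this assay. This position therefore distinguishes between two halogens, and exchanging a single atom, with no change in ring, hydrogen-bond donors, hydrogen-bond acceptors or net charge, is enough to give a weaker inhibitor beyond the scatter, something the pair of compound 1 and compound 2, which differ in more than one place, could not isolate. No measurement shown bears on the origin of this step, which remains unassigned.

As far as these compounds go, only bromo and chloro are compared at this place on the core of compound 1, so the response to fluoro, methoxy or an amine there remains open. From the compounds shown here alone, whether chloro in place of iodo on the core of compound 2 would give a step of similar size also remains open.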